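A few compounds are considered here, and "the series" means these few. Any claim that something is new, unique, unknown or untested is made for them only; others in the source may bear on it.

Measured in a functional assay on the whole organism (strain Kunming) with Mus musculus as the target, with a stated time of 0.5 h; on this read-out higher numbers stand for an effect only at larger amounts of compound and lower numbers for an effect already at smaller amounts:
Compound 1 `COc1cc(OC)c(OC)cc1/C=C/COC(=O)/C=C/c1cc(OC)c(OC)c(OC)c1OC`: 155 mg/kg
Compound 2 `COc1cc(OC)c(OC)cc1/C=C/COC(=O)/C=C/c1cccc(Br)c1`: > 200 mg/kg

Compound 2 stands at > 200 mg/kg, which is a limit of this assay and not a number. Its true position is therefore open.

Compound 3 `COc1cc(OC)c(OC)cc1/C=C/COC(=O)/C=C/c1ccc(Cl)cc1` keeps the rest of compound 2 and carries 4-chlorophenyl in place of 3-bromophenyl on a double-bonded chain carbon bound to a double-bonded chain carbon.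

Among the compounds with values here, no measured step bears on this change. Within the data shown here, the only numeric reading so far is for compound 1 at 155 mg/kg, so compound 3 is expected to read close to that number. Compound 3 may instead end at a limit, as compound 2 does at > 200 mg/kg. A small move toward lower numbers in this assay is expected, not beyond the usual scatter: an at least 1.1-fold lower number from compound 2 to compound 3 (0.07 log units; that floor lies within the scatter). For compound 3 the estimated value is 170 mg/kg, with an expected range of 90 mg/kg to 300 mg/kg.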

Compound 3, dose for half-maximal effect: 142 mg/kg
Estimate against measurement, compound 3: 1.2-fold (0.08 log units) above, within the range that was stated.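

In this assay compound 3 gives 142 mg/kg, so this position, on a double-bonded chain carbon bound to a double-bonded chain carbon, now has a numeric reading with a halogen-bearing phenyl, which compound 2 did not supply. The change to 4-chlorophenyl in place of 3-bromophenyl gives an at least 1.4-fold lower number from compound 2 to compound 3 (0.14 log units; that floor lies within the scatter), so no shift beyond the scatter is established. Compound 2 sits at a limit, so the step is known only as a floor: the limit of > 200 mg/kg in this assay, at which 1 of the 3 values shown sits.

The step changes the halogen and its place on the ring together, and the compounds shown do not separate the two. From the compounds shown here alone, how 3-chlorophenyl, 4-bromophenyl or a phenyl carrying an amine would read at this position remains open.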